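The source may report more compounds than this note shows. Statements on the series, on what has been measured and on what is new or still open speak of the compounds shown alone.

Measured in a functional assay on MDA-MB-231 cells (Homo sapiens) for cytotoxicity, read by ELISA, with a stated time of 2 days; a lower number here means a stronger inhibitor, a higher number a weaker inhibitor
- compound 1 `Oc1cccc(-c2cc(-c3ccccc3)cc(-c3ccccc3)n2)c1` gives 19300 nM
- compound 2 `Oc1cccc(-c2cc(-c3ccccc3)cc(-c3ccsc3)n2)c1` gives 12100 nM

Not yet measured: compound 3 `Oc1ccc(-c2cc(-c3ccccc3)cc(-c3ccccc3)n2)cc1`

Among the measured compounds shown here, compound 1 stands within the scatter of compound 2, the only other measured compound. Compound 3 differs from compound 1 in one place (4-hydroxyphenyl in place of 3-hydroxyphenyl on an aromatic carbon), with 4-hydroxyphenyl in place of 3-hydroxyphenyl on an aromatic carbon. For the measured compounds named here, the one measured step (a 1.6-fold lower number from compound 1 to compound 2 (0.20 log units; within the scatter)) is thiophen-3-yl in place of phenyl, so it bears only indirectly, and no measured step changes the hydroxyphenyl group. No step beyond the scatter is therefore expected in this assay in either direction, and the estimated step is small (a 1.2-fold lower number from compound 1 to compound 3 (0.08 log units; within the scatter)). For compound 3 the estimated value is 16000 nM (expected range 7000 nM to 36000 nM).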

Compound 3, half-maximal inhibitory concentration: 1300 nM
Estimate against measurement, compound 3: 12-fold (1.09 log units) above; the measured number lies below the stated range.
By their numbers in this assay, from the lowest: compound 3; then compounds 2 and 1 (each within the scatter of the next).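

In this assay, the hydroxyl position on the aryl group next to the ring nitrogen proves decisive: a 15-fold lower number from compound 1 to compound 3 (1.17 log units; beyond the scatter). The two groups have the same atoms and the same counts, so the step comes from their arrangement alone, and this position responds far more than the earlier thiophen-3-yl change did. No available data account for this difference.

From the compounds shown here alone, whether 4-hydroxyphenyl gives a similar step alongside the thiophen-3-yl group of compound 2 remains open. So does whether a methoxy group or an amine can replace the hydroxyl at that ring position.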